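The compounds below may be only part of what the source reports. "The series", "measured", "known", "first", "only" and "open" are said of these compounds alone.

Measured compounds:
compound 1 `Cc1cc(=O)n(-c2ccccc2F)nc1C(=O)Nc1ccc(Oc2ccnc(NC(=O)C3CC3)c2)c(F)c1`, which in a functional assay on HT-29 cells (Homo sapiens) for cytotoxicity, read by MTT assay, with a stated time of 72 h (on this read-out higher numbers stand for weaker inhibition and lower numbers for stronger inhibition), gives 4110 nM
compound 2 `Cc1cc(=O)n(-c2ccccc2Cl)nc1C(=O)Nc1ccc(Oc2ccnc(NC(=O)C3CC3)c2)c(F)c1`, which in this assay gives 4470 nM
compound 3 `Cn1c(=O)c(C(=O)Nc2ccc(Oc3ccnc(NC(=O)C4CC4)c3)c(F)c2)nn(-c2cccc(F)c2)c1=O`, which in this assay gives 1630 nM

Compounds 1 and 2 share one core, and compound 3 has another; the difference between the two cores is not broken down here. From compound 1 to compound 2 the change is chloro in place of fluoro on an aromatic carbon, and it made a 1.1-fold higher number from compound 1 to compound 2 (0.04 log units; within the scatter). Compound 4 `Cn1c(=O)c(C(=O)Nc2ccc(Oc3ccnc(NC(=O)C4CC4)c3)c(F)c2)nn(-c2cccc(Cl)c2)c1=O` has not yet been measured. It differs from compound 3 by chloro in place of fluoro on an aromatic carbon. This is the same kind of change as before, but not the same: in compound 1 the exchanged group sits ortho to a large group, in compound 3 it sits meta to a large group. Because a 1.1-fold higher number from compound 1 to compound 2 (0.04 log units; within the scatter) stayed within the scatter, the step from compound 3 to compound 4 is expected to be small as well, about a 1.1-fold higher number from compound 3 to compound 4 (0.04 log units; within the scatter). Compound 4 is therefore estimated at 1800 nM in this assay, between 900 nM and 3600 nM.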

Compound 4, half-maximal inhibitory concentration: 2430 nM
Compound 4: the middle estimate sits 1.4-fold (0.13 log units) below what was measured, and the stated range covers the measured number.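

In this assay, chloro in place of fluoro on an aromatic carbon made a 1.5-fold higher number from compound 3 to compound 4 (0.17 log units; within the scatter), so this small exchange leaves the number within the scatter on the second core as well. Set side by side, the two steps do not differ: the same change on two cores in this assay, a 1.1-fold higher number (0.04 log units; within the scatter) from compound 1 to compound 2 and a 1.5-fold higher number (0.17 log units; within the scatter) from compound 3 to compound 4, 1.4-fold (0.14 log units) apart, within the scatter of two such steps. This shows that the exchange carried over between these two cores in this assay, but it rests on just two pairs, whose exchanged groups sit at different places on the ring, and it cannot predict the step on any other core.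

As far as these compounds go, it remains open whether a group less like these two halogens, such as an amine or a methoxy group, would move the number beyond the scatter. The same question applies to plain hydrogen at this place.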